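Piperidine for oxane on the ring nitrogen: clearance notes

A few compounds are considered here, and "the series" means these few. Any claim that something is new, unique, unknown or untested is made for them only; others in the source may bear on it.

Compound 1 `Cc1cc2ncccc2cc1Nc1ncc2c(n1)n(C1CCOCC1)c(=O)n2C` and compound 2 `Cc1cc2nccnc2cc1Nc1ncc2c(n1)n(C1CCOCC1)c(=O)n2C` share most of their structure; the difference between the two cores is not broken down here. In an ADME assay on microsomes from liver (Homo sapiens) for metabolic stability (on this read-out lower numbers stand for slow clearance and higher numbers for fast clearance), compound 1 gives 30 mL.min-1.g-1 and compound 2 gives 6.9 mL.min-1.g-1. Compound 3 `Cc1cc2ncccc2cc1Nc1ncc2c(n1)n(C1CCN(C)CC1)c(=O)n2C` carries 1-methylpiperidin-4-yl in place of oxan-4-yl on an aromatic nitrogen relative to compound 1. In this assay compound 3 is reported only as a limit, < 4 mL.min-1.g-1. The step of an at least 7.5-fold lower number from compound 1 to compound 3 (0.87 log units; beyond the scatter) is therefore bounded by the limit of < 4 mL.min-1.g-1 in this assay, at which 1 of the 3 values shown sits. Compound 4 `Cc1cc2nccnc2cc1Nc1ncc2c(n1)n(C1CCN(C)CC1)c(=O)n2C` is the unmeasured partner: it carries 1-methylpiperidin-4-yl in place of oxan-4-yl on an aromatic nitrogen relative to compound 2, the same change at the same place. The step from compound 2 to compound 4 is expected to be of similar size to the earlier one, resting on an at least 7.5-fold lower number from compound 1 to compound 3 (0.87 log units; beyond the scatter), so compound 4 is estimated at a 3.5-fold lower number from compound 2 to compound 4 (0.54 log units; beyond the scatter) and will likely also be reported only as a limit. Compound 4 is expected to give 2 mL.min-1.g-1 in this assay, between 0.8 mL.min-1.g-1 and 5 mL.min-1.g-1.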

Compound 4, intrinsic clearance in microsomes: < 4 mL.min-1.g-1
Compound 4 ended at the assay's limit; the forecaster's own chance of this, stated with the estimate: 70%; the middle value lies beyond the limit too.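

In this assay compound 4 is reported only as a limit, < 4 mL.min-1.g-1. Placing 1-methylpiperidin-4-yl in place of oxan-4-yl on this core gives an at least 1.7-fold lower number from compound 2 to compound 4 (0.23 log units; that floor lies within the scatter), so the result does not go against the earlier step, but on its own it does not establish a real drop on this core. Whether the change carries over with the same size cannot be read from the two steps: the same change on two cores in this assay, an at least 7.5-fold lower number (0.87 log units; beyond the scatter) from compound 1 to compound 3 and an at least 1.7-fold lower number (0.23 log units; that floor lies within the scatter) from compound 2 to compound 4; the limit leaves it open whether they differ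

From the compounds shown here alone, the true size of the step on either core stays open, since both compounds bearing 1-methylpiperidin-4-yl give only a limit: the limit of < 4 mL.min-1.g-1 in this assay, at which 2 of the 4 values shown sit. Also open is how other groups on this aromatic nitrogen, such as a piperidine without the methyl group or an open-chain amine, would compare.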